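Chloro in Place of Bromo: Expected Cytotoxicity of Compound 4

The compounds below may be only part of what the source reports. "The series", "measured", "known", "first", "only" and "open" are said of these compounds alone.

Three compounds have been measured in an ADME assay on HeLa cells (Homo sapiens) for cytotoxicity, read by resazurin assay, with a stated time of 2 days; on this read-out higher numbers stand for weaker inhibition and lower numbers for stronger inhibition:

compound 1 `Cn1c([N+](=O)[O-])cnc1/C=C/c1ccccc1Br` gives 72400 nM.
compound 2 `Cn1c([N+](=O)[O-])cnc1/C=C/c1cccc(Br)c1` gives 87100 nM.
compound 3 `Cn1c([N+](=O)[O-])cnc1/C=C/c1ccccc1Cl` gives only a limit, > 100000 nM.

Compound 1 and compound 2 are built from the same atoms joined differently; the difference between the two cores is not broken down here. The values of compound 1 and compound 2 lie within the scatter of each other.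

From compound 1 to compound 3 the change is chloro in place of bromo on an aromatic carbon, and it gave an at least 1.3-fold higher number from compound 1 to compound 3 (0.14 log units; that floor lies within the scatter), a floor set by the limit of > 100000 nM in this assay, at which 1 of the 3 values shown sits.

Compound 4 `Cn1c([N+](=O)[O-])cnc1/C=C/c1cccc(Cl)c1` has not been measured. It arises from compound 2 by the same kind of change, (chloro in place of bromo on an aromatic carbon), the place here being meta rather than ortho to a large group. Since compound 2 gives 87100 nM, the expected step is a 1.5-fold higher number from compound 2 to compound 4 (0.17 log units; within the scatter), resting on the step from compound 1 to compound 3. Compound 4 is therefore estimated at 130000 nM, between 65000 nM and 260000 nM.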

Compound 4, half-maximal inhibitory concentration: 30200 nM
Compound 4: the middle estimate sits 4.3-fold (0.63 log units) above what was measured; the measured number lies below the stated range.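

In this assay, chloro in place of bromo gave a 2.9-fold lower number from compound 2 to compound 4 (0.46 log units; beyond the scatter) on the core of compound 2, so the change did not carry over from one core to the other: the same change on two cores in this assay, an at least 1.3-fold higher number (0.14 log units; that floor lies within the scatter) from compound 1 to compound 3 and a 2.9-fold lower number (0.46 log units; beyond the scatter) from compound 2 to compound 4, at least 3.9-fold (0.60 log units) apart, beyond the scatter of two such steps. The earlier step is known only as a floor, as compound 3 gives a limit and not a number: the limit of > 100000 nM in this assay, at which 1 of the 4 values shown sits. These two pairs do not show why the steps part, nor which of them, if either, would hold on a further core in this series.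

The compounds shown leave open how a fluoro or a methoxy group would read in place of the halogen. They also leave open whether an amine or a carboxylic acid on the same ring would alter the outcome of the swap.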